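Pyrimidine anilines: sulfur pentafluoride, hydrogen, methoxyphenyl

A few compounds are considered here, and "the series" means these few. Any claim that something is new, unique, unknown or untested is made for them only; others in the source may bear on it.

Measured so far:
compound 1 `Cc1cc(Nc2cc(Cl)cc(S(F)(F)(F)(F)F)c2)nc(N)n1` — > 180000 nM
compound 2 `Cc1cc(Nc2cccc(Cl)c2)nc(N)n1` — > 180000 nM

In an assay on cells for inhibition of S-adenosylmethionine decarboxylase proenzyme (Homo sapiens), read by mass spectrometry, at pH 7.2 (on this read-out higher numbers stand for weaker inhibition and lower numbers for stronger inhibition), compound 1 returns only a limit. In this assay compound 2 likewise gives only a limit, so its standing on the numbers shown is a limit, not a measured inhibitory concentration. Among the compounds with values here, the one step between measured compounds, a step that the two limits leave unreadable from compound 1 to compound 2, cannot be read because both ends sit on the limit, as the limit of > 180000 nM in this assay, at which 2 of the 2 values shown sit, records.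

Compound 3 `COc1ccc(-c2cc(Cl)cc(Nc3cc(C)nc(N)n3)c2)cc1` is the next compound for this assay. Relative to compound 2 the change is 4-methoxyphenyl in place of hydrogen on an aromatic carbon. Within the data shown here, no measured step speaks to this change: the only step, from compound 1 to compound 2, concerns a different group and is unreadable. With both measured compounds at the limit, no direction can be taken from the data. The expectation for compound 3 therefore rests on the series as it stands and is a step that the limit leaves unreadable from compound 2 to compound 3, with a strong chance that compound 3 also returns only a limit. The estimate for compound 3 is 200000 nM, ranging from 30000 nM to 1000000 nM.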

Compound 3, half-maximal inhibitory concentration: > 180000 nM
Compound 3: no number, only a limit (the forecaster's own chance of this, stated with the estimate: 70%); the middle value does not contradict the limit.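

Compound 3 also returns only a limit in this assay, so neither new step, to compound 3 from compound 2 or from compound 1, can be read: the limit of > 180000 nM in this assay, at which 3 of the 3 values shown sit.

The compounds shown leave open whether any change to the shared core gives a measurable inhibitory concentration, and how large the effect of the sulfur pentafluoride or 4-methoxyphenyl group would be.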